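From 3-methoxyphenyl to 4-methoxyphenyl in compound 1

The source may report more compounds than this note shows. Statements on the series, on what has been measured and on what is new or still open speak of the compounds shown alone.

In a functional assay on HeLa cells (Homo sapiens) for antiproliferative activity, read by MTT assay, with a stated time of 72 h (a lower number here means a stronger inhibitor, a higher number a weaker inhibitor), compound 1 `C=CC(=O)Nc1cccc(Oc2nc(Nc3cccc(OC)c3)nc3c2CSCC3)c1` gives 28900 nM and compound 2 `CC/C=C/C(=O)Nc1cccc(Oc2nc(Nc3cccc(OC)c3)nc3c2CSCC3)c1` gives 27200 nM, two numbers within the scatter of each other. For compound 3 `COc1cccc(Nc2nc3c(c(Oc4cccc(NC(=O)/C=C/C(C)C)c4)n2)CSCC3)c1`, this assay reports only a limit, > 50000 nM.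

Compound 4 `C=CC(=O)Nc1cccc(Oc2nc(Nc3ccc(OC)cc3)nc3c2CSCC3)c1` keeps the core of compound 1 but carries 4-methoxyphenyl in place of 3-methoxyphenyl on a nitrogen on an aromatic ring. For the measured compounds named here, no measured step touches that place. The measured steps all change the group on the carbonyl carbon, and they offer only indirect guidance: a 1.1-fold lower number from compound 1 to compound 2 (0.03 log units; within the scatter), and an at least 1.7-fold higher number from compound 1 to compound 3 (0.23 log units; that floor lies within the scatter). No change beyond the scatter is therefore expected in this assay, and the expected step is a 1.2-fold lower number from compound 1 to compound 4 (0.06 log units; within the scatter). Compound 4 is estimated at 25000 nM, with an expected range of 9000 nM to 50000 nM.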

Compound 4, half-maximal inhibitory concentration: 20900 nM
For compound 4 the middle estimate is 1.2-fold (0.08 log units) above the measured one; measured number inside the range.
By their numbers in this assay, from the lowest: compounds 4, 2 and 1 (each within the scatter of the next). At a limit, above all of these: compound 3.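

For the compounds shown here, the first measured change at this place, 4-methoxyphenyl in place of 3-methoxyphenyl on the nitrogen, gives in this assay a 1.4-fold lower number from compound 1 to compound 4 (0.14 log units; within the scatter). The two methoxyphenyl groups thus cannot be told apart here with vinyl on the carbonyl carbon. Nothing shown accounts for this result.

Going by these compounds, it remains open whether an unsubstituted phenyl, or a phenyl bearing an amine or a carboxylic acid, would give a number beyond the scatter. On these data alone, it is also open whether the same swap would behave alike with but-1-en-1-yl on the carbonyl carbon.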